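Swapping amino for chloro on a purine-like core

A few compounds are considered here, and "the series" means these few. Any claim that something is new, unique, unknown or untested is made for them only; others in the source may bear on it.

Compound 1 `Nc1nc(Cl)c2ncn(Cc3ccccc3CCl)c2n1` was tested in a functional assay on SK-MEL-5 cells (Homo sapiens) for cytotoxicity, read by sulforhodamine B assay, with a stated time of 48 h (on this read-out lower numbers stand for stronger inhibition of growth and higher numbers for weaker inhibition of growth), where compound 1 gives 8510 nM. Of the three compounds measured, compound 1 carries the second highest number. Compound 2 `Nc1nc(Cl)c2ncn(Cc3ccc(CCl)cc3)c2n1` gives 15500 nM, which sits within the usual scatter of compound 1. Compound 3 `ClCc1ccccc1Cn1cnc2nc(Cl)nc(Cl)c21` gives 740 nM, a number well beyond the scatter below compound 1; compound 3 also carries two chloro groups on its core. Compound 4 `ClCc1ccccc1Cn1cnc2c(Cl)nc(Cl)nc21` has not yet been measured. The change from compound 1 to compound 4 is chloro in place of amino on an aromatic carbon. Since compound 3 with two chloro groups gives 740 nM, compound 4 is expected to fall below compound 1, with a step of about a 5.7-fold lower number from compound 1 to compound 4 (0.75 log units; beyond the scatter). Compound 4 is therefore estimated at 1500 nM, within a range from 400 nM to 6000 nM.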

Compound 4, concentration for 50% growth inhibition: 420 nM
Estimate against measurement, compound 4: 3.6-fold (0.55 log units) above, and the stated range covers the measured number.
By their numbers in this assay, from the lowest: compounds 4 and 3 (each within the scatter of the next); then compounds 1 and 2 (each within the scatter of the next).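

For the compounds shown here, this is the first step that changes one place only. In this assay, chloro in place of amino on the aromatic carbon between two ring nitrogen atoms gives a 20-fold lower number from compound 1 to compound 4 (1.31 log units; beyond the scatter) and counts as a large step, so growth inhibition depends strongly on the group at this position. No measurement shown here accounts for the size of this step. The compounds shown leave open how a methyl group, a methoxy group or a plain hydrogen at this position would compare. Such groups could show whether the step follows from losing amino or from adding chloro.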